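The source may hold more compounds than are shown below. What is called first, only, known or untested is meant among the compounds shown, and "the series" means these compounds.

Within the data shown here, compound 1 `COc1cccc(/C=C/C(=O)/C=C/c2ccc(OCc3cn(CCCCCOc4cc(=O)oc5ccccc45)nn3)c(OC)c2)c1` gives 37% in a functional assay on THP-1 cells (Homo sapiens) for inhibition, read by sulforhodamine B assay, with a stated time of 48 h, tested at 50 uM (on this read-out higher numbers stand for more inhibition of growth at the one concentration tested and lower numbers for less inhibition of growth), and compound 2 `COc1cc(/C=C/C(=O)/C=C/c2cc(OC)c(OC)c(OC)c2)ccc1OCc1cn(CCCCCOc2cc(=O)oc3ccccc23)nn1` gives 55% there, the higher of the two numbers so far. Compound 3 `COc1cc(/C=C/C(=O)/C=C/c2ccco2)ccc1OCc1cn(CCCCCOc2cc(=O)oc3ccccc23)nn1` differs from compound 2 by furan-2-yl in place of 3,4,5-trimethoxyphenyl on a double-bonded chain carbon bound to a double-bonded chain carbon on a double-bonded chain carbon bound to a double-bonded chain carbon. Among the measured compounds shown here, one measured step bears on this place: a number 18 percentage points higher from compound 1 to compound 2 (beyond the scatter) with 3,4,5-trimethoxyphenyl in place of 3-methoxyphenyl, modest but beyond the scatter. For the measured compounds named here, no furan-2-yl compound has a number yet, so the loss of 3,4,5-trimethoxyphenyl is expected to cost about that much. The expected change is a number 17 percentage points lower from compound 2 to compound 3 (beyond the scatter) in this assay. The estimate for compound 3 is 38% (expected range 22% to 55%).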

Compound 3, percent growth inhibition at one concentration: 39%
The estimate for compound 3 lay 1 percentage points below the measured number; the range from low to high includes it.
By their numbers in this assay, from the lowest: compounds 1 and 3 (each within the scatter of the next); then compound 2.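

In this assay the trimethoxyphenyl result now stands out at this place, on a double-bonded chain carbon bound to a double-bonded chain carbon: the step to furan-2-yl gives a number 16 percentage points lower from compound 2 to compound 3 (beyond the scatter). The other step gives a number 2 percentage points higher from compound 1 to compound 3 (within the scatter), so furan-2-yl and 3-methoxyphenyl cannot be told apart here. Nothing on hand accounts for the edge of 3,4,5-trimethoxyphenyl.

Open, on these data alone, is whether a pyridin-3-yl ring or a phenyl ring carrying a carboxylic acid at this place would match compound 2 55%. Also open, as far as these compounds go, is whether these steps hold with a longer chain in place of the pentyl linker.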